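Triazole-linked sugars: aryl swap and lipophilicity

A few compounds are considered here, and "the series" means these few. Any claim that something is new, unique, unknown or untested is made for them only; others in the source may bear on it.

Measured compounds:
Compound 1, `OC[C@H]1O[C@H](n2cc(-c3cccc(Cl)c3)nn2)[C@@H](O)[C@@H](O)[C@@H]1O`, 1.22.
Compound 2, `OC[C@H]1O[C@H](n2cc(-c3cccnc3)nn2)[C@@H](O)[C@@H](O)[C@@H]1O`, -1.04.
Compound 3, `OC[C@H]1O[C@H](Cn2cc(-c3cccc(Cl)c3)nn2)[C@@H](O)[C@@H](O)[C@@H]1O`, 0.68.

All three were run in a physicochemical assay for lipophilicity, read by LC-MS, using the shake flask method, in phosphate buffer, measured as octanol-water partition, with a stated time of 2 h, at pH 7.4; a lower number here means a more polar compound, a higher number a more lipophilic compound. Compound 1 gives 1.22 and compound 2 gives -1.04. Between them stands one change, (pyridin-3-yl in place of 3-chlorophenyl on an aromatic carbon), and it made a step of a number 2.26 log units lower from compound 1 to compound 2 (beyond the scatter). Compound 3 gives 0.68, a lower number than compound 1 and a higher number than compound 2. How the core of compound 3 differs from the core of compound 1 is not broken down here.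

Compound 4, `OC[C@H]1O[C@H](Cn2cc(-c3cccnc3)nn2)[C@@H](O)[C@@H](O)[C@@H]1O`, has not yet been measured in this assay. It differs from compound 3 by pyridin-3-yl in place of 3-chlorophenyl on an aromatic carbon. Among the measured compounds shown here, the surroundings of the place are described in the same words for both pairs, so this is the same change as the one from compound 1 to compound 2, made now on the core of compound 3.

The expectation for compound 4 rests on a single earlier example: the step made by this change once, a number 2.26 log units lower from compound 1 to compound 2 (beyond the scatter), was large and beyond the scatter. The step expected on the core of compound 3 is a number 2.26 log units lower from compound 3 to compound 4 (beyond the scatter). Compound 4 is therefore estimated at -1.58, with a likely range from -2.2 to -0.9. For the measured compounds named here, since only one prior instance supports this, the range is kept wide; a second measurement of the same change on a second core would show whether the step size carries over.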

Compound 4, distribution coefficient: < -1.5
Compound 4 was reported as a limit; the forecaster's own chance of this, stated with the estimate: 5%; the middle value is on the limit's open side.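

In this assay, compound 4 is reported only as a limit of the assay and not as a number: the limit of < -1.5 in this assay, at which 1 of the 4 values shown sits.

Even so, the step can be read in one direction: pyridin-3-yl in place of 3-chlorophenyl gives a step of a number at least 2.18 log units lower from compound 3 to compound 4 (beyond the scatter), which runs the same way as the step of a number 2.26 log units lower from compound 1 to compound 2 (beyond the scatter) on the core of compound 1, and both are large, so on these two cores the change carries over in direction and remains large. From the compounds shown here alone, its exact size on the core of compound 3 stays unknown, so the notes cannot say whether the two steps match or whether one core responds more strongly than the other, and two pairs establish no rule for other cores.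

The compounds shown place only 3-chlorophenyl and pyridin-3-yl at this position on the triazole-bearing side, so it remains open how a primary amine or a carboxylic acid there would read in this assay. Going by these compounds, it also remains open whether the same swap would give a step of this kind on a core with a longer chain than that of compound 3.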